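This account rests on a few compounds, and the source may have more. Where it says the series, first, only, none or still open, it means among the compounds named here.

Measured in a functional assay on NCI-H460 cells (Homo sapiens) for cytotoxicity, read by MTT assay, with a stated time of 72 h (a lower number here means a stronger inhibitor, a higher number a weaker inhibitor), so far:
- Compound 1 `CC(C)c1[nH]cnc1/C=c1\[nH]c(=O)/c(=C/c2cccc(Oc3ccc(F)cc3)c2)[nH]c1=O` gives 8.8 nM
- Compound 2 `O=c1[nH]/c(=C\c2cccc(Oc3ccc(F)cc3)c2)c(=O)[nH]/c1=C\c1ccccc1` gives 389 nM
- Compound 3 `O=c1[nH]/c(=C\c2ccc([N+](=O)[O-])o2)c(=O)[nH]/c1=C\c1cccc(Oc2ccc(F)cc2)c1` gives > 1000 nM (a limit, not a number)

Compound 3 has no exact value and stands at the limit of > 1000 nM in this assay, at which 1 of the 3 values shown sits (a limit only). Compound 4 `Cc1ccc(/C=c2\[nH]c(=O)/c(=C/c3cccc(Oc4ccc(F)cc4)c3)[nH]c2=O)o1` turns the 5-nitrofuran-2-yl of compound 3 into 5-methylfuran-2-yl, with methyl in place of nitro on an aromatic carbon.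

Going by the values given here, no measured step makes this exact swap, so the nearest guides are changes to the same group. Two were large (a 44-fold higher number from compound 1 to compound 2 (1.65 log units; beyond the scatter)) and (an at least 110-fold higher number from compound 1 to compound 3 (2.05 log units; beyond the scatter)), and both removed the 5-isopropyl-1H-imidazol-4-yl, which compound 4 also lacks. A smaller one was at least modest (an at least 2.5-fold higher number from compound 2 to compound 3 (0.41 log units; beyond the scatter)), so a nitrofuran gave a higher number than a phenyl.

A modest move toward a lower number in this assay therefore seems likely, though compound 4 could also stay at the limit. The expected step is an at least 2.5-fold lower number from compound 3 to compound 4 (0.39 log units; beyond the scatter) (an estimate). The estimate for compound 4 is 400 nM (expected range 100 nM to 1500 nM).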

Compound 4, half-maximal inhibitory concentration: 30 nM
Estimate against measurement, compound 4: 13-fold (1.12 log units) above; measured number below the stated range.
By their numbers in this assay, from the lowest: compound 1; then compound 4; then compound 2. At a limit, above all of these: compound 3.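

Compound 4 shows that a furan need not fail here, since methyl in place of nitro on the same aromatic carbon is a large change, and the size of that change is only a bound, because compound 3 has a limit and not a number: the limit of > 1000 nM in this assay, at which 1 of the 4 values shown sits. The step itself reads an at least 33-fold lower number from compound 3 to compound 4 (1.52 log units; beyond the scatter), so the group on this carbon, not the furan alone, decides the result. A 5-methylfuran-2-yl also beats a plain phenyl (a 13-fold lower number from compound 2 to compound 4 (1.11 log units; beyond the scatter)) and comes much closer to the 5-isopropyl-1H-imidazol-4-yl, though a real gap remains (a 3.4-fold higher number from compound 1 to compound 4 (0.53 log units; beyond the scatter)).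

Only nitro and methyl are shown on this carbon, so an amine, a chlorine or a longer chain such as ethyl remains open. Why methyl and nitro differ so widely also stays unexplained.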